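The compounds below may be only part of what the source reports. "The series", "measured", "known", "first", "only" and "open" are said of these compounds alone.

For the measured compounds named here, compound 3 `CN1[C@@H]2c3[nH]c4ccccc4c3C[C@H]1[C@H](C#N)N1[C@@H](CNC(=O)c3ccc4ccccc4c3)c3[nH]c4ccccc4c3C[C@@H]21` sits at the top of the three numbers measured so far: in a functional assay on A2780 cells (Homo sapiens) for cytotoxicity, read by MTT assay, with a stated time of 72 h (on this read-out lower numbers stand for stronger inhibition and higher numbers for weaker inhibition), compound 3 gives 1030 nM, against compound 1 `COc1ccc(C(=O)NC[C@H]2c3[nH]c4ccccc4c3C[C@H]3[C@H]4c5[nH]c6ccccc6c5C[C@@H]([C@H](C#N)N23)N4C)cc1` with 320 nM and compound 2 `CN1[C@@H]2c3[nH]c4ccccc4c3C[C@H]1[C@H](C#N)N1[C@@H](CNC(=O)c3ccc(F)cc3)c3[nH]c4ccccc4c3C[C@@H]21` with 250 nM. The two steps leading to it, a 3.2-fold higher number from compound 1 to compound 3 (0.51 log units; beyond the scatter) and a 4.1-fold higher number from compound 2 to compound 3 (0.61 log units; beyond the scatter), both move beyond the scatter in the same direction, whereas the step of a 1.3-fold lower number from compound 1 to compound 2 (0.11 log units; within the scatter) stays within it. Compound 4 `CN1[C@@H]2c3[nH]c4ccccc4c3C[C@H]1[C@H](C#N)N1[C@@H](CNC(=O)c3cc4ccccc4s3)c3[nH]c4ccccc4c3C[C@@H]21` differs from compound 3 by 1-benzothiophen-2-yl in place of naphthalen-2-yl on a carbonyl carbon. Going by the values given here, no measured step pairs two bicyclic groups on this carbonyl carbon, so the only bearing information is that the bicyclic naphthalen-2-yl gave higher numbers than either single-ring group. With one bicyclic aromatic group exchanged for another of nearly the same count of heavy atoms, the expected step of a 1.1-fold lower number from compound 3 to compound 4 (0.06 log units; within the scatter) is none beyond the scatter. Compound 4 is therefore estimated at 900 nM in this assay, within 400 nM to 2000 nM.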

Compound 4, half-maximal inhibitory concentration: 20 nM
The estimate for compound 4 lay 45-fold (1.65 log units) above the measured number, outside the stated range (below it).
By their numbers in this assay, from the lowest: compound 4; then compounds 2 and 1 (each within the scatter of the next); then compound 3.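

In this assay, the group on this carbonyl carbon does not act as one bicyclic class: a 52-fold lower number from compound 3 to compound 4 (1.71 log units; beyond the scatter), which places naphthalen-2-yl and 1-benzothiophen-2-yl at opposite ends of the four numbers. The single-ring groups are also passed, with a 13-fold lower number from compound 2 to compound 4 (1.10 log units; beyond the scatter) and a 16-fold lower number from compound 1 to compound 4 (1.20 log units; beyond the scatter), so the earlier higher number for a bicyclic group holds for compound 3 only, and compound 4 goes against it. No measured evidence accounts for this change at the carbonyl carbon.

On these data alone, whether the lower number follows the sulfur or the five-membered aromatic ring remains open, and a 1-benzofuran-2-yl or indol-2-yl group at this place would bear on that. Also open, as far as these compounds go, is whether an amine or a carboxylic acid on the 1-benzothiophen-2-yl ring would keep the number near that of compound 4.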